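Moving a hydroxy and a methoxy on one ring

The source may report more compounds than this note shows. Statements on the series, on what has been measured and on what is new or still open speak of the compounds shown alone.

In a functional assay on CNE-2 cells (Homo sapiens) for antiproliferative activity, read by sulforhodamine B assay, with a stated time of 48 h (on this read-out higher numbers stand for weaker inhibition and lower numbers for stronger inhibition), compound 1 (`COc1ccc(C=C(C(=O)/C=C/c2cccc(OC)c2OC)C(=O)/C=C/c2cccc(OC)c2OC)cc1OC`) gives 280 nM and compound 2 (`COc1cccc(/C=C/C(=O)C(=Cc2ccc(OC)c(OC)c2OC)C(=O)/C=C/c2cccc(OC)c2OC)c1OC`) gives 410 nM while compound 3 (`COc1ccc(OC)c(/C=C/C(=O)C(=Cc2ccc(O)c(OC)c2)C(=O)/C=C/c2cc(OC)ccc2OC)c1`) gives 340 nM on the same scale. Compound 3 stands within the scatter of both compound 1 and compound 2, so these numbers cannot be told apart. Compound 4 (`COc1ccc(OC)c(/C=C/C(=O)C(=Cc2ccc(OC)c(O)c2)C(=O)/C=C/c2cc(OC)ccc2OC)c1`) has not been measured yet. It differs from compound 3 by one exchange (3-hydroxy-4-methoxyphenyl in place of 4-hydroxy-3-methoxyphenyl on a double-bonded chain carbon bound to a double-bonded chain carbon) with 3-hydroxy-4-methoxyphenyl in place of 4-hydroxy-3-methoxyphenyl on a double-bonded chain carbon bound to a double-bonded chain carbon. Among the compounds with values here, the only measured step (a 1.5-fold higher number from compound 1 to compound 2 (0.17 log units; within the scatter)) puts methoxy in place of hydrogen on an aromatic carbon and stays within the scatter. Within the data shown here, that is a different kind of change, and no measurement yet shows an exchange like this one, so it is only a loose guide. In this assay a step (a 1.0-fold lower number from compound 3 to compound 4 (0.01 log units; within the scatter)) no larger than the scatter is therefore expected, with no clear direction. For compound 4 the estimated value is 330 nM with an expected span from 165 nM to 660 nM around it.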

Compound 4, half-maximal inhibitory concentration: 730 nM
Compound 4: the middle estimate sits 2.2-fold (0.34 log units) below what was measured; the whole stated range lies below it.
By their numbers in this assay, from the lowest: compounds 1, 3, 2 and 4 (each within the scatter of the next, the first and the last beyond it).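

Within the data shown here, exchanging 4-hydroxy-3-methoxyphenyl for 3-hydroxy-4-methoxyphenyl on a double-bonded chain carbon bound to a double-bonded chain carbon gives a 2.1-fold higher number from compound 3 to compound 4 (0.33 log units; beyond the scatter) in this assay and is the first step here to pass the usual scatter. The two groups have the same atoms and the same counts of hydrogen-bond donors and acceptors, so how the hydroxy and methoxy are arranged on this ring is enough to separate the two numbers, while putting a methoxy in place of hydrogen gave only a 1.5-fold higher number from compound 1 to compound 2 (0.17 log units; within the scatter) on a different ring. No measured evidence explains why this rearrangement counts.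

From the compounds shown here alone, what an amine or a fluorine would do in place of the hydroxy on this ring remains open. So does whether the same exchange would count on the other aromatic rings.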